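A few compounds are considered here, and "the series" means these few. Any claim that something is new, unique, unknown or untested is made for them only; others in the source may bear on it.

Compound 2, with the structure `C[C@@H](O)[C@H]1C(=O)N2C(C(=O)O)=C(C(C)(C)C)O[C@@H]12`, gives 6.4 h in an ADME assay, in phosphate buffer, at 28 degrees C, at pH 7.0; a higher number here means that the compound lasts longer, a lower number that the compound disappears faster. This is the higher of the two numbers recorded, but only just: compound 1, `COC(=O)[C@@H](O)[C@H]1C(=O)N2C(C(=O)O)=C(C(C)(C)C)O[C@H]12`, gives 6.2 h in this assay, and the two values sit within the usual scatter of each other, so no order between them can be claimed. The next compound, compound 3, has the structure `C[C@H](O)[C@H]1C(=O)N2C(C(=O)O)=C(C(C)(C)C)O[C@H]12`. Its relation to compound 2 is a matter of configuration alone: the two compounds have the same atoms and bonds and differ only in configuration as drawn: 2 of 3 stereo elements differ; a stereocentre at a saturated chain carbon is drawn R in compound 2 and S in compound 3; a stereocentre at a saturated ring carbon is drawn S in compound 2 and R in compound 3. Among the compounds with values here, no pair of measured compounds shows a step of this kind, so the size of the effect has to be guessed from what the two measured values show, and they show a flat picture so far. The step from compound 2 to compound 3 is expected to be a 1.1-fold lower number from compound 2 to compound 3 (0.03 log units; within the scatter), that is, nothing beyond the scatter. Compound 3 is therefore estimated to give 6 h in this assay, somewhere between 3 h and 12 h.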

Compound 3, half-life: 7.1 h
For compound 3 the middle estimate is 1.2-fold (0.07 log units) below the measured one, within the range that was stated.
By their numbers in this assay, from the lowest: compounds 1, 2 and 3 (each within the scatter of the next).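

In this assay, the change in drawn configuration gives a 1.1-fold higher number from compound 2 to compound 3 (0.05 log units; within the scatter), so this stereo change at a saturated chain carbon and a saturated ring carbon stays within the scatter. Placing 1-hydroxyethyl instead of hydroxy(methoxycarbonyl)methyl on a saturated ring carbon gives a 1.1-fold higher number from compound 1 to compound 3 (0.06 log units; within the scatter), which also stays within the scatter and gives the first reading of a change of group at this position. The first of these two readings involves no change of group: the fact that compounds 2 and 3 differ only in the configuration as drawn

Since two stereo elements differ together, the compounds shown cannot separate the contribution of either stereocentre. They also leave open whether an amine in place of the hydroxy group, or a longer chain on the same saturated ring carbon, would give a half-life beyond the scatter.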